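The compounds below may be only part of what the source reports. "The series", "measured", "known", "first", "only" and "open" are said of these compounds alone.

Working notes on the series, measured in a functional assay on MCF7 cells (Homo sapiens) for cytotoxicity, read by MTT assay, with a stated time of 48 h; a higher number here means a weaker inhibitor, a lower number a stronger inhibitor.

Compound 1 `COc1cc(-c2nnc3n2NC(c2ccco2)C(C(=O)c2ccc(Cl)cc2)S3)cc(OC)c1OC` gives > 100000 nM in this assay, which is a limit of the assay and not a number, as recorded in the limit of > 100000 nM in this assay, at which 1 of the 3 values shown sits. Compound 2 `COc1cc(-c2nnc3n2NC(c2cccs2)C(C(=O)c2ccc(C)cc2)S3)cc(OC)c1OC` gives 28400 nM in this assay. Compound 3 `COc1ccc(C(=O)C2Sc3nnc(-c4cc(OC)c(OC)c(OC)c4)n3NC2c2cccs2)cc1` gives 49500 nM in this assay. Among the compounds with values here, the one measured step, a 1.7-fold higher number from compound 2 to compound 3 (0.24 log units; within the scatter), leaves the two values indistinguishable.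

Compound 4 `COc1cc(-c2nnc3n2NC(c2ccco2)C(C(=O)c2ccc(F)c(F)c2)S3)cc(OC)c1OC` is not yet measured. Its change from compound 1 is 3,4-difluorophenyl in place of 4-chlorophenyl on a carbonyl carbon. Within the data shown here, no measured pair carries a change of this kind on the carbonyl-bound aromatic ring; the only measured step, methoxy in place of methyl, sits on a different ring substituent in compounds that also differ from compound 1 elsewhere, and it stayed within the scatter. So there is nothing in these data pointing to a shift in either direction, and compound 1 is itself only known as a limit.

The step from compound 1 to compound 4 is therefore expected to be an at least 1.1-fold lower number from compound 1 to compound 4 (0.04 log units; that floor lies within the scatter), meaning no change beyond the scatter. The estimate for compound 4 in this assay is 90000 nM, with a range from 30000 nM to 250000 nM, and a real chance that only a limit is again reported.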

Compound 4, half-maximal inhibitory concentration: 73200 nM
Estimate against measurement, compound 4: 1.2-fold (0.09 log units) above; the measured number falls inside the stated range.
By their numbers in this assay, from the lowest: compounds 2, 3 and 4 (each within the scatter of the next, the first and the last beyond it). At a limit, above all of these: compound 1.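

In this assay, compound 4 gives a measured value of 73200 nM, so 3,4-difluorophenyl in place of 4-chlorophenyl on a carbonyl carbon yields a measured number. Within the data shown here, this is the first change on this aromatic ring to be measured with the rest of the structure held constant, and it reads as an at least 1.3-fold lower number from compound 1 to compound 4 (0.13 log units; that floor lies within the scatter), so the data show no change beyond the scatter, though a larger step is not excluded. The real size of the step stays open, as the value of compound 1 is a limit of the assay and not a number: the limit of > 100000 nM in this assay, at which 1 of the 4 values shown sits.

On these data alone, whether any group at this place moves the number beyond the scatter remains open, and an amine such as dimethylamino or a carboxylic acid on this aromatic ring would test a different kind of substituent from the halogens in compound 1 and compound 4. As far as these compounds go, compound 2 and compound 3 differ from compound 4 in more than one place, so whether their methyl and methoxy substituents would give similar numbers in the background of compound 4 also remains open.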